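Methylamino to 4-methylpiperazin-1-yl on the shared core

The source may hold more compounds than are shown below. What is called first, only, known or untested is meant among the compounds shown, and "the series" means these compounds.

The compounds measured so far in a toxicity assay on J774.A1 cells (Mus musculus) for cytotoxicity, read by SYBR Green assay, with a stated time of 1 h (on this read-out higher numbers stand for an effect only at larger amounts of compound and lower numbers for an effect already at smaller amounts), are two:
- Compound 1 `CN(C)c1ccc2cc(-c3ccccc3F)c(N)nc2c1` gives 1600 nM
- Compound 2 `CNc1ccc2cc(-c3cn(C)c4ccccc34)c(N)nc2c1` gives 4100 nM

Going by the values given here, compound 2 at 4100 nM holds the higher of the two numbers, with compound 1 at 1600 nM as its only neighbour, and the gap between them lies beyond the usual scatter of repeated measurements. Compound 3 `CN1CCN(c2ccc3cc(-c4cn(C)c5ccccc45)c(N)nc3c2)CC1` keeps the core of compound 2 and carries a single change 4-methylpiperazin-1-yl in place of methylamino on an aromatic carbon in which 4-methylpiperazin-1-yl stands in place of methylamino on an aromatic carbon. Among the compounds with values here, no pair of measured compounds differs in one place only, so the data give no direct measure of such an exchange. The two measured compounds differ in more than one place, and their gap cannot be assigned to any one group. In this assay no step beyond the scatter is therefore expected in either direction, and the expectation rests on compound 2 at 4100 nM as the closest anchor. The expected step is a 1.4-fold lower number from compound 2 to compound 3 (0.14 log units; within the scatter) and it is estimated to stay small. For compound 3 the estimated value is 3000 nM with an expected range from 1000 nM to 10000 nM on this read-out.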

Compound 3, half-maximal effective concentration: 1000 nM
The estimate for compound 3 lay 3.0-fold (0.48 log units) above the measured number, and the stated range covers the measured number.
By their numbers in this assay, from the lowest: compounds 3 and 1 (each within the scatter of the next); then compound 2.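

In this assay, going by these compounds alone, the exchange of methylamino for 4-methylpiperazin-1-yl on an aromatic carbon gives the first measure of a change in one place, a 4.1-fold lower number from compound 2 to compound 3 (0.61 log units; beyond the scatter), a modest step that lies beyond the usual scatter. It shows that this position of the shared core is not silent on this read-out: with the rest of compound 2 unchanged, replacing a group with no ring by one six-membered non-aromatic ring with 2 hetero atoms moves the effect to smaller amounts of compound. Nothing measured here bears on what lies behind this step.

The single exchange changes the ring, the size of the group and the hydrogen-bond donor together, so the compounds shown leave open which of these features goes with the step, and morpholin-4-yl or piperazin-1-yl without its methyl would be the neighbouring groups to compare at this position. They also leave open whether 4-methylpiperazin-1-yl would give a step of similar size and direction on the core of compound 1, which differs from compound 2 in more than one place.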